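The source may report more compounds than this note shows. Statements on the series, on what has been measured and on what is new or still open speak of the compounds shown alone.

Measured compounds:
- compound 1, `O=C(Nc1nnc(-c2ccc(Cl)cc2)s1)c1ccccc1`: > 5010 nM
- compound 2, `O=C(Nc1nnc(-c2ccc(Cl)cc2)s1)c1c(F)cccc1F`: > 5010 nM
- compound 3, `O=C(Nc1nnc(-c2ccc(Cl)cc2)s1)c1c(Cl)cccc1Cl`: 380 nM

Of the compounds shown here, three on a shared core have been tested in a functional assay on the whole organism (integument) for inhibition, with Chilo suppressalis as the target, read by scintillation counting, with a stated time of 72 h; on this read-out higher numbers stand for weaker inhibition and lower numbers for stronger inhibition. Compound 1 gives only a limit, > 5010 nM. Compound 2 likewise gives only a limit, > 5010 nM. Going by the values given here, compound 3 is the one compound with a number, 380 nM, and it therefore stands alone; the other two values sit at the limit of > 5010 nM in this assay, at which 2 of the 3 values shown sit, so no measured step can be sized. Compound 4, `O=C(Nc1nnc(-c2ccc(Cl)cc2)s1)c1ccccc1Cl`, has yet to be tested in this assay. It differs from compound 3 by hydrogen in place of chloro on an aromatic carbon. Compound 1, which carries no chloro on that six-membered aromatic ring, reaches only its limit, while compound 3 with two chloro groups gives a number; compound 4 with a single chloro is therefore expected to fall between them, weaker than compound 3 by a step of a 3.9-fold higher number from compound 3 to compound 4 (0.60 log units; beyond the scatter). For compound 4 the estimate is 1500 nM, within 400 nM to 5000 nM.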

Compound 4, half-maximal inhibitory concentration: > 5010 nM
Compound 4: only a limit was reported; the forecaster's own chance of this, stated with the estimate: 30%; at least 3.3-fold (0.52 log units) between middle value and limit.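

In this assay, hydrogen in place of chloro on this aromatic carbon brings an at least 13-fold higher number from compound 3 to compound 4 (1.12 log units; beyond the scatter), so this one chloro group carries a large part of the inhibition measured for compound 3. The result also shows that a single remaining chloro on the six-membered aromatic ring does not bring a number back: compound 4 gives only a limit, > 5010 nM. The step between compound 1 and compound 4 cannot be read, as both values are limits, and any difference among the weaker compounds stays hidden: the limit of > 5010 nM in this assay, at which 3 of the 4 values shown sit.

On these data alone, whether bromo or methyl on that carbon would keep a value like that of compound 3 remains open. As far as these compounds go, how far compound 4 lies past its limit also remains open.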